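Ethoxycarbonyl in place of 4-butylcyclohexyl: compound 4

The compounds below may be only part of what the source reports. "The series", "measured", "known", "first", "only" and "open" are said of these compounds alone.

In an ADME assay on Vero 76 cells (Chlorocebus sabaeus) for cytotoxicity, read by crystal violet staining, with a stated time of 96 h (on this read-out lower numbers stand for higher toxicity in this test and higher numbers for lower toxicity in this test), three compounds have been measured so far. Compound 1 (`FC(F)(F)c1cccc(NC(=S)Nc2ccc(I)cc2)c1`) gives 9500 nM, compound 2 (`CCCC[C@H]1CC[C@H](c2ccc(NC(=S)Nc3cccc(C(F)(F)F)c3)cc2)CC1`) gives 17000 nM and compound 3 (`O=C(NC(=S)Nc1cccc(C(F)(F)F)c1)[C@H]1C[C@@H]2CC[C@H]1C2`) gives 20000 nM. Compound 2 lies within the scatter of both compound 1 and compound 3, so it holds no distinct place in this small set.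

Compound 4 (`CCOC(=O)c1ccc(NC(=S)Nc2cccc(C(F)(F)F)c2)cc1`) is not yet measured. It carries ethoxycarbonyl in place of 4-butylcyclohexyl on an aromatic carbon, para to a large group: ethoxycarbonyl in place of 4-butylcyclohexyl on an aromatic carbon.

Going by the values given here, only one measured step changes a group at this place: a 1.8-fold higher number from compound 1 to compound 2 (0.25 log units; within the scatter), with 4-butylcyclohexyl in place of iodo. That step stays within the scatter. Among the compounds with values here, compound 3 offers no single-place step to compound 2. Within the data shown here, no measured compound carries ethoxycarbonyl, so the evidence for this group is indirect and the range must stay wide.

No step beyond the scatter is therefore expected in this assay. The expected change is a 1.1-fold lower number from compound 2 to compound 4 (0.05 log units; within the scatter), a shift no larger than the scatter. Compound 4 is estimated at 15000 nM, with an expected range of 6000 nM to 35000 nM.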

Compound 4, half-maximal cytotoxic concentration: 71000 nM
The estimate for compound 4 lay 4.7-fold (0.68 log units) below the measured number; the measured number lies above the stated range.
By their numbers in this assay, from the lowest: compounds 1, 2 and 3 (each within the scatter of the next, the first and the last beyond it); then compound 4.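

In this assay, this position on the aromatic ring now shows a clear dependence on the group it carries: ethoxycarbonyl in place of 4-butylcyclohexyl gives a 4.2-fold higher number from compound 2 to compound 4 (0.62 log units; beyond the scatter), and ethoxycarbonyl in place of iodo gives a 7.5-fold higher number from compound 1 to compound 4 (0.87 log units; beyond the scatter), whereas the exchange of iodo for 4-butylcyclohexyl alone gave only a 1.8-fold higher number from compound 1 to compound 2 (0.25 log units; within the scatter). On this read-out, both new steps point to lower toxicity in this test for the ethoxycarbonyl compound, so the position is not as indifferent to substitution as the earlier pair suggested. The exchange from 4-butylcyclohexyl changes several things at once, removing the non-aromatic ring and the defined stereocentres while bringing in oxygen and hydrogen-bond acceptors, and nothing available here ties the higher number to any one of these differences.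

On these data alone, it remains open whether the shift belongs to the ester itself or would also appear with a carboxylic acid, a primary amide or a methoxy group at this place. A longer ester chain, such as butoxycarbonyl, would show whether the number holds as the group grows back towards the size of 4-butylcyclohexyl.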